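The compounds below may be only part of what the source reports. "The series", "measured", "known", "first", "only" and "open" are said of these compounds alone.

Working notes on a small set built on the shared core of compound 1 `CC1=C([Se]CC(OC(=O)[C@@H](CO)NC(=O)OC(C)(C)C)C(=O)NCCCCCC(=O)OCc2ccccc2)C(=O)c2ccccc2C1=O`. Within the data shown here, in a functional assay on A-431 cells (Homo sapiens) for cytotoxicity, read by MTT assay, with a stated time of 24 h (on this read-out higher numbers stand for weaker inhibition and lower numbers for stronger inhibition), compound 1 gives 4000 nM, and it is the only compound in the set that returns a number. Compound 2 `CC1=C(SCCC(=O)OC(C[Se]c2ccccc2)C(=O)NCCCCCC(=O)OCc2ccccc2)C(=O)c2ccccc2C1=O` belongs to the same set. In this assay compound 2 gives only a limit, > 100000 nM, which is the limit of > 100000 nM in this assay, at which 1 of the 2 values shown sits. Among the measured compounds shown here, no pair of measured compounds differs in one place, so no measured step is available, and compound 1 stands as the sole numeric reference. Compound 3 `CC1=C([Se]CC(OC(=O)CNC(=O)OC(C)(C)C)C(=O)NCCCCCC(=O)OCc2ccccc2)C(=O)c2ccccc2C1=O` is not yet measured. It differs from compound 1 as follows: hydrogen in place of hydroxymethyl on a saturated chain carbon bound to an amide-type nitrogen and a carbonyl carbon. The remainder of compound 1 is kept. With no measured step of this kind in the set, the expectation is that the change does not move the read-out beyond the usual scatter, or only slightly toward weaker inhibition. The step expected from compound 1 to compound 3 is a 1.4-fold higher number from compound 1 to compound 3 (0.14 log units; within the scatter). Compound 3 is therefore estimated at 5500 nM in this assay, with a range from 2000 nM to 16000 nM.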

Compound 3, half-maximal inhibitory concentration: 5000 nM
Estimate against measurement, compound 3: 1.1-fold (0.04 log units) above; measured number inside the range.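

In this assay, among these compounds, the series now has its first measured step, a 1.3-fold higher number from compound 1 to compound 3 (0.10 log units; within the scatter), and this step is the only direct reading of the position: hydrogen in place of hydroxymethyl on a saturated chain carbon bound to an amide-type nitrogen and a carbonyl carbon. Compound 1 is thus no longer the sole numeric reference, and for this pair the hydroxymethyl, with its hydrogen-bond donor and acceptor, can leave without the read-out moving beyond the scatter. Nothing measured in the set speaks to a cause for this step.

The compounds shown leave open how an amine, a carboxylic acid or a longer alkyl chain on this carbon would read in this assay, as the position is sampled only by hydroxymethyl and hydrogen. Also open is what the tert-butoxycarbonyl group on the neighbouring amide-type nitrogen contributes to the read-out, with no pair shown that changes that group alone.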